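From hydroxy to carboxy on the shared core

The compounds below may be only part of what the source reports. "The series", "measured", "known", "first", "only" and "open" are said of these compounds alone.

The measured compounds in a functional assay on Hep 3B2 cells (Homo sapiens) for antiproliferative activity, read by MTT assay, with a stated time of 24 h, tested at 100 ug/mL; on this read-out higher numbers stand for a stronger effect at the one concentration tested and lower numbers for a weaker effect:
compound 1 `CCc1ccc2nc(C(=O)Nc3c(F)cc(-c4cccc(F)c4)cc3F)c(C)c(O)c2c1`, 63.2%
compound 2 `Cc1c(C(=O)Nc2c(F)cc(-c3cccc(F)c3)cc2F)nc2ccc(F)cc2c1O`, 75.2%
compound 3 `Cc1c(C(=O)Nc2c(F)cc(-c3cccc(F)c3)cc2F)nc2ccc(C(F)(F)F)cc2c1O`, 68.4%

Compound 1 stands lowest of the three. Its gap to compound 3 is a number 5.2 percentage points higher from compound 1 to compound 3 (within the scatter), which lies within the scatter, and its gap to compound 2 is a number 12 percentage points higher from compound 1 to compound 2 (beyond the scatter), which lies beyond it. Between compound 2 and compound 3 the step is a number 6.8 percentage points lower from compound 2 to compound 3 (within the scatter), again within the scatter.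

Compound 4 `CCc1ccc2nc(C(=O)Nc3c(F)cc(-c4cccc(F)c4)cc3F)c(C)c(C(=O)O)c2c1` is not yet measured. It differs from compound 1 by carboxy in place of hydroxy on an aromatic carbon.

All three measured steps change the group at the ethyl-bearing position, and they stay small or modest. Among the compounds with values here, none of them touches the hydroxy, so no measured step bears directly on the change to carboxy. With no guidance from the data, the expected step of a number 5.2 percentage points lower from compound 1 to compound 4 (within the scatter) is no step beyond the scatter, with a wide range to cover the unknown. Compound 4 is therefore estimated at 58%, between 35% and 78%.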

Compound 4, a percentage reported as inhibition, at one concentration (the size of the read-out at that concentration, not a potency): 64.3%
For compound 4 the middle estimate is 6.3 percentage points below the measured one, within the range that was stated.
By their numbers in this assay, from the lowest: compounds 1, 4, 3 and 2 (each within the scatter of the next, the first and the last beyond it).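

Within the data shown here, until now only the ethyl-bearing position had varied, and compound 4 gives the first reading at the aromatic carbon opposite the ring nitrogen. In this assay, carboxy in place of hydroxy gives a number 1.1 percentage points higher from compound 1 to compound 4 (within the scatter), so although the entering group has 3 heavy atoms and the leaving group 1, this read-out at a single concentration does not separate the two compounds. No measurement shown here offers an explanation for this result.

The compounds shown leave open what an amine or a methoxy group would give at this same place. They also leave open whether carboxy would give a similar reading alongside the fluoro of compound 2 or the trifluoromethyl of compound 3.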